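This account rests on a few compounds, and the source may have more. Where it says the series, first, only, none or still open, it means among the compounds named here.

Measured in a functional assay on BXPC-3 cells (Homo sapiens) for antiproliferative activity, read by MTT assay, with a stated time of 24 h; on this read-out higher numbers stand for weaker inhibition and lower numbers for stronger inhibition:

- compound 1 `CCn1c(C(=O)N[C@@H](C)C(=O)OC)ccc1C(CC)(CC)c1ccc(OCS(=O)(=O)c2ccccc2)c(C)c1` gives 17900 nM
- compound 2 `CCn1c(C(=O)NCC(=O)OC)ccc1C(CC)(CC)c1ccc(OCS(=O)(=O)c2ccccc2)c(C)c1` gives 20000 nM
- compound 3 `CCn1c(C(=O)N[C@@H](C)CO)ccc1C(CC)(CC)c1ccc(OCS(=O)(=O)c2ccccc2)c(C)c1` gives 15300 nM

Compound 3 stands level with the other two compounds, since its gaps to them are within the scatter: a 1.2-fold lower number from compound 1 to compound 3 (0.07 log units; within the scatter) and a 1.3-fold lower number from compound 2 to compound 3 (0.12 log units; within the scatter) are both too small to read as real differences.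

The next compound is compound 4 `CCn1c(C(=O)N[C@H](C)CO)ccc1C(CC)(CC)c1ccc(OCS(=O)(=O)c2ccccc2)c(C)c1`. Its change is the subtlest kind: the two compounds have the same atoms and bonds and differ only in configuration as drawn: 1 of 1 stereo elements differ; a stereocentre at a saturated chain carbon is drawn S in compound 3 and R in compound 4 and nothing else. It is a mirror-image switch at one carbon, so a stereocentre at a saturated chain carbon is drawn S in compound 3 and R in compound 4.

Among the measured compounds shown here, no measured pair differs in configuration alone, so the data offer no direct precedent. The nearest evidence concerns that same carbon and its surroundings. Replacing the methyl there with hydrogen gave a 1.1-fold higher number from compound 1 to compound 2 (0.05 log units; within the scatter) and stayed within the scatter. Changing the neighbouring methoxycarbonyl to hydroxymethyl gave a 1.2-fold lower number from compound 1 to compound 3 (0.07 log units; within the scatter) and did the same. This series has so far responded little to edits in this part of the molecule, though three compounds are a thin basis, and a change of configuration can still behave differently.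

No shift beyond the scatter is therefore expected, and the expected step is a 1.0-fold higher number from compound 3 to compound 4 (0.02 log units; within the scatter) in this estimate. For compound 4 the estimated value is 16000 nM with an expected range of 8500 nM to 30000 nM in this assay.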

Compound 4, half-maximal inhibitory concentration: 10000 nM
Estimate against measurement, compound 4: 1.6-fold (0.20 log units) above; the range from low to high includes it.
By their numbers in this assay, from the lowest: compounds 4, 3, 1 and 2 (each within the scatter of the next).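

In this assay, among the compounds shown here, the mirror-image switch at the saturated chain carbon gives a 1.5-fold lower number from compound 3 to compound 4 (0.18 log units; within the scatter), so this is the first direct test of configuration at this position, and it does not separate the two compounds. The side chain on the amide-type nitrogen tells the same story for the R form, with a 2.0-fold lower number from compound 2 to compound 4 (0.30 log units; within the scatter) and a 1.8-fold lower number from compound 1 to compound 4 (0.25 log units; within the scatter), so all three steps stay inside the scatter and none can be read as a real gain, even though the step from compound 2 reaches the edge of it. The 3>4 step is also the cleanest comparison in the set, since any gap between this pair can only come from that one carbon: the fact that compounds 3 and 4 differ only in the configuration as drawn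

The four compounds do not show whether a carboxylic acid or an amine in place of the hydroxymethyl, or a longer chain in place of the methyl on that carbon, would move the number beyond the scatter. Going by these compounds, it also remains open whether configuration at this carbon matters more when the methoxycarbonyl group stands there, as the mirror image of compound 1 would show.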